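Cyclohexylmethoxy in Place of Cyclohexyl on Compound 2

This account rests on a few compounds, and the source may have more. Where it says the series, first, only, none or still open, it means among the compounds named here.

Compound 2 `Cc1cccc(NC(=O)c2nn(C)c(C3CCCCC3)c2C)n1` is one of two measured members of this series. In a functional assay on HEK293 cells for negative allosteric modulation of metabotropic glutamate receptor 5 (Homo sapiens), read by FLIPR and calcium flux (a higher number here means a weaker inhibitor, a lower number a stronger inhibitor), compound 2 gives 25 nM, the higher of the two numbers. For the measured compounds named here, compound 1 `Cc1cccc(NC(=O)c2nn(C)c(-c3ccccc3)c2C)n1` differs from it only in carrying a phenyl group where compound 2 carries a cyclohexyl; in this assay compound 1 gives 4.4 nM, and the step of a 5.7-fold higher number from compound 1 to compound 2 (0.75 log units; beyond the scatter) is the only one available for comparison. Compound 3 `Cc1cccc(NC(=O)c2nn(C)c(OCC3CCCCC3)c2C)n1` is not yet measured. It differs from compound 2 in one place: cyclohexylmethoxy in place of cyclohexyl on an aromatic carbon. Going by the values given here, no measured pair shows what a cyclohexylmethoxy group does at this aromatic carbon, so the one known step bears on it only loosely: it shows that exchanging the group at this position moved the number modestly, from phenyl to cyclohexyl toward a higher value. On that basis a step of similar or smaller size is expected, in either direction, with a slight lean toward a higher number. Compound 3 is estimated to give 40 nM in this assay, within 8 nM to 200 nM, which corresponds to an expected step of a 1.6-fold higher number from compound 2 to compound 3 (0.20 log units; within the scatter).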

Compound 3, half-maximal inhibitory concentration: 1300 nM
Compound 3: the middle estimate sits 33-fold (1.51 log units) below what was measured; measured number outside the range, above it.
By their numbers in this assay, from the lowest: compound 1; then compound 2; then compound 3.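

For the compounds shown here, the position proves far less forgiving than the one earlier step suggested: in this assay, the exchange of cyclohexyl for cyclohexylmethoxy gives a 52-fold higher number from compound 2 to compound 3 (1.72 log units; beyond the scatter), a large step where the exchange of phenyl for cyclohexyl had been only modest. Set against the phenyl group, the exchange is larger still, at a 300-fold higher number from compound 1 to compound 3 (2.47 log units; beyond the scatter), so the groups at this aromatic carbon now span a wide range of numbers, and the two attached directly through a ring keep the number far lower than cyclohexylmethoxy does. The same six-membered carbon ring is present in compound 2 and compound 3, which places the large step with the added oxygen and carbon that join it to the core, yet nothing measured here explains the loss.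

Whether the oxygen or the extra carbon carries the step stays open, since the compounds shown include neither a cyclohexylmethyl group nor a cyclohexyloxy group at this carbon. They also leave unknown how a phenoxy group, a benzyloxy group or a small methoxy group would read at this position.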